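Methoxy Traded for Nitrile on the Aryl Ring

This account rests on a few compounds, and the source may have more. Where it says the series, first, only, none or still open, it means among the compounds named here.

Compound 2 `COc1cccc(-c2nnn(CC(=O)Nc3cc(C)nn3C3CCCCC3)n2)c1` gives the lowest of the two numbers in an assay on HEK293 cells for activation of Kir3.1/Kir3.2 (Homo sapiens), read by thallium flux (a higher number here means that more compound is needed for the effect, a lower number that less compound is needed), at 117 nM. Among the measured compounds shown here, its only neighbour, compound 1 `Cc1cc(NC(=O)Cn2nnc(-c3cccnc3)n2)n(C2CCCCC2)n1`, gives 1930 nM in this assay; the single measured step, a 16-fold lower number from compound 1 to compound 2 (1.22 log units; beyond the scatter), came from replacing pyridin-3-yl with 3-methoxyphenyl. Compound 3 `Cc1cc(NC(=O)Cn2nnc(-c3cccc(C#N)c3)n2)n(C2CCCCC2)n1` differs from compound 2 by cyano in place of methoxy on an aromatic carbon. For the measured compounds named here, no measured step bears directly on exchanging methoxy for cyano, so no move beyond the scatter is expected, with only a mild lean towards a higher number. Compound 3 is therefore estimated at 250 nM, within 60 nM to 1000 nM, which would mean a 2.1-fold higher number from compound 2 to compound 3 (0.33 log units; beyond the scatter).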

Compound 3, half-maximal effective concentration: 183 nM
For compound 3 the middle estimate is 1.4-fold (0.14 log units) above the measured one; the measured number falls inside the stated range.
By their numbers in this assay, from the lowest: compounds 2 and 3 (each within the scatter of the next); then compound 1.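

In this assay, cyano and methoxy on this aromatic carbon cannot be told apart, with a 1.6-fold higher number from compound 2 to compound 3 (0.19 log units; within the scatter). The large step away from pyridin-3-yl therefore does not depend on methoxy alone: 3-cyanophenyl in its place gives an 11-fold lower number from compound 1 to compound 3 (1.02 log units; beyond the scatter). Nothing available explains why these two groups give such similar numbers here.

Still open, on these data alone, is how a chlorine atom, an amine or a carboxylic acid would fare on this same aromatic carbon. As far as these compounds go, whether cyano and methoxy also match on a different core remains open too.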